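Microsomal stability notes: urea-to-sultam swap at the benzylic carbon

The source may hold more compounds than are shown below. What is called first, only, known or untested is meant among the compounds shown, and "the series" means these compounds.

Measured so far:
- compound 1 `CCn1ncc2c(F)cc(-c3ccc(C(CC)(CC)c4ncn(C)n4)c(=O)[nH]3)cc21` — > 3 h
- compound 2 `CC(C)C(c1ccc(-c2ccc3cccc(F)c3c2)[nH]c1=O)N1CCNC1=O` — 0.682 h
- compound 3 `CCC(CC)(c1nnc[nH]1)c1ccc(-c2ccc3cccc(F)c3c2)[nH]c1=O` — 0.447 h

In an ADME assay on microsomes from liver (Mus musculus) for metabolic stability (a lower number here means that the compound disappears faster, a higher number that the compound lasts longer), compound 1 reaches only a limit of the assay, > 3 h, and gives no number (the limit of > 3 h in this assay, at which 1 of the 3 values shown sits). Among the two compounds with a number, compound 2 holds the higher one in this assay with 0.682 h, though compound 3 with 0.447 h sits within the scatter of it, so no order between the two can be claimed.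

Compound 4 `CC(C)C(c1ccc(-c2ccc3cccc(F)c3c2)[nH]c1=O)N1CCCCS1(=O)=O` is not yet measured. It differs from compound 2 by a group of 8 heavy atoms (4 carbon, 1 nitrogen, 2 oxygen, 1 sulfur; one six-membered non-aromatic ring with 2 hetero atoms) in place of a group of 6 heavy atoms (3 carbon, 2 nitrogen, 1 oxygen; one five-membered non-aromatic ring with 2 hetero atoms), on a saturated chain carbon bound to an aromatic carbon and a saturated chain carbon. For the measured compounds named here, no measured pair in the set isolates such a swap, so there is no precedent here for its size or direction.

Expectation: the step from compound 2 to compound 4 in this assay is expected to stay within the usual scatter, a 1.2-fold higher number from compound 2 to compound 4 (0.07 log units; within the scatter). Compound 4 is therefore estimated at 0.8 h, with a range from 0.35 h to 1.8 h.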

Compound 4, half-life: 0.0733 h
The estimate for compound 4 lay 11-fold (1.04 log units) above the measured number; the whole stated range lies above it.
By their numbers in this assay, from the lowest: compound 4; then compounds 3 and 2 (each within the scatter of the next). At a limit, above all of these: compound 1.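

In this assay, placing the six-membered non-aromatic ring with 2 hetero atoms where the 2-oxoimidazolidin-1-yl group stood gives a 9.3-fold lower number from compound 2 to compound 4 (0.97 log units; beyond the scatter), which is beyond the scatter. For the compounds shown here, this is the first isolated change on the saturated chain carbon bound to an aromatic carbon and a saturated chain carbon, and it shows that the group held there can alone move the half-life substantially, with the rest of the structure unchanged. Going by these compounds alone, the single step changes ring size, hetero atoms and hydrogen-bond donor and acceptor counts together, so it assigns the drop to none of these.

The data shown give no reason for the drop. From the compounds shown here alone, a six-membered cyclic urea on this carbon would separate ring size from the sulfur-containing ring, and whether the step holds on the core of compound 1 stays open.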